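The compounds below may be only part of what the source reports. "The series", "measured", "known", "first", "only" and "open" are said of these compounds alone.

Measured compounds:
- compound 1, `CN(C(=O)NC(=O)c1ccccc1F)c1nc(C(F)(F)F)c(C(=O)N/N=C/c2ccc(C(F)(F)F)cc2)s1`: 3.97 ug/mL
- compound 2, `CN(C(=O)NC(=O)c1ccc([N+](=O)[O-])cc1)c1nc(C(F)(F)F)c(C(=O)N/N=C/c2cccc(C(F)(F)F)c2)s1`: 4.12 ug/mL
- compound 3, `CN(C(=O)NC(=O)c1ccccc1F)c1nc(C(F)(F)F)c(C(=O)N/N=C/c2ccccc2C(F)(F)F)s1`: 10.1 ug/mL

In a functional assay on HeLa cells (Homo sapiens) for inhibition, read by MTT assay, with a stated time of 72 h (on this read-out higher numbers stand for weaker inhibition and lower numbers for stronger inhibition), compound 1 gives the lowest of the three numbers. Compound 2 gives a number within the scatter of it, so the two cannot be told apart. Within the data shown here, compound 3 gives a number beyond the scatter, and the only single-point step, a 2.5-fold higher number from compound 1 to compound 3 (0.41 log units; beyond the scatter), concerns the aryl group on the carbon with a double bond to nitrogen.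

Compound 4, `CN(C(=O)NC(=O)c1ccc(C(F)(F)F)cc1)c1nc(C(F)(F)F)c(C(=O)N/N=C/c2ccc(C(F)(F)F)cc2)s1`, is not yet measured. It differs from compound 1 at another place: 4-(trifluoromethyl)phenyl in place of 2-fluorophenyl on a carbonyl carbon. Among the measured compounds shown here, no measured step changes the group on the carbonyl carbon alone; compound 2 carries a different group there but also a different aryl on the carbon with a double bond to nitrogen, so its value shows nothing about this change by itself. For the measured compounds named here, with no step bearing on it, no change beyond the scatter is expected in this assay.

Compound 4 is therefore expected to give about 4.5 ug/mL, between 2 ug/mL and 10 ug/mL, which means an estimated step of a 1.1-fold higher number from compound 1 to compound 4 (0.05 log units; within the scatter).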

Compound 4, half-maximal inhibitory concentration: > 100 ug/mL
Compound 4: no number, only a limit; the forecaster's own chance of this, stated with the estimate: 5%; middle value at least 22-fold (1.34 log units) from the limit.
By their numbers in this assay, from the lowest: compounds 1 and 2 (each within the scatter of the next); then compound 3. At a limit, above all of these: compound 4.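

In this assay compound 4 gives > 100 ug/mL, which is a limit of the assay and not a number. The group on the carbonyl carbon had not been varied on its own before, and this comparison shows that the activity depends heavily on it: putting 4-(trifluoromethyl)phenyl in place of 2-fluorophenyl gives an at least 25-fold higher number from compound 1 to compound 4 (1.40 log units; beyond the scatter). The full size of this step stays unknown, since the new value is only a limit: the limit of > 100 ug/mL in this assay, at which 1 of the 4 values shown sits.

The compounds shown leave open whether the loss follows from removing the 2-fluorophenyl group or from bringing in the 4-(trifluoromethyl)phenyl group, as this single swap changes both at once. Nor do they show how a plain phenyl ring, or a non-aromatic group such as a short alkyl chain, would behave on this carbonyl carbon.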